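Chain variation on the aromatic nitrogen: compound 4

The source may hold more compounds than are shown below. What is called first, only, known or untested is meant among the compounds shown, and "the series" means these compounds.

Measured compounds:
- compound 1, `CCCCCCn1cnc2c(Nc3ccc(O)cc3)nc(N[C@H]3CC[C@H](N)CC3)nc21`; in a functional assay on EOL1 cells (Homo sapiens) for inhibition, read by fluorescence, with a stated time of 72 h (a lower number here means a stronger inhibitor of growth, a higher number a weaker inhibitor of growth), compound 1 gives 190 nM
- compound 2, `CC(C)CCn1cnc2c(Nc3cccc(O)c3)nc(N[C@H]3CC[C@H](N)CC3)nc21`; in this assay compound 2 gives 60 nM
- compound 3, `CCCCCCn1cnc2c(Nc3cccc(Cl)c3)nc(N[C@H]3CC[C@H](N)CC3)nc21`; in this assay compound 3 gives 310 nM

Compound 3 has the highest number of the three. Compound 1 is nearest to it, and the step of a 1.6-fold higher number from compound 1 to compound 3 (0.21 log units; within the scatter) is within the scatter. Among the compounds with values here, compound 2 is furthest from compound 3, and that gap lies beyond the scatter, but compound 2 differs from compound 3 in two places, so no single step is defined for that pair.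

Compound 4, `CC(C)=CCn1cnc2c(Nc3cccc(Cl)c3)nc(N[C@H]3CC[C@H](N)CC3)nc21`, differs from compound 3 as follows: 2-methylprop-1-en-1-yl in place of pentyl on a saturated chain carbon bound to an aromatic nitrogen. Within the data shown here, none of the measured steps touches the chain on the aromatic nitrogen; the only single-point step, that of compound 1 to compound 3, concerns the group on the nitrogen of the shared core and is within the scatter. Among the measured compounds shown here, no measured step therefore bears on this change, and in this assay no step beyond the scatter is expected, in either direction.

For compound 4 the expected value in this assay is 300 nM, with a range from 100 nM to 900 nM, which means an expected step of a 1.0-fold lower number from compound 3 to compound 4 (0.01 log units; within the scatter).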

Compound 4, concentration for 50% growth inhibition: 80 nM
Estimate against measurement, compound 4: 3.8-fold (0.57 log units) above, outside the stated range (below it).
By their numbers in this assay, from the lowest: compounds 2 and 4 (each within the scatter of the next); then compounds 1 and 3 (each within the scatter of the next).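

The chain on the aromatic nitrogen affects the number in this assay: with the 3-chlorophenyl group held fixed, 3-methylbut-2-en-1-yl in place of hexyl gives a 3.9-fold lower number from compound 3 to compound 4 (0.59 log units; beyond the scatter), a step beyond the scatter. Within the data shown here, the only earlier single-place step, a 1.6-fold higher number from compound 1 to compound 3 (0.21 log units; within the scatter), concerned the group on the nitrogen of the shared core and stayed within the scatter, so this chain is the one place where a single change has yet moved the number beyond it. Nothing at hand bears on the reason for this step.

This one pair cannot separate the double bond from the branching or the chain length, and it leaves open whether the step holds with 3-hydroxyphenyl or 4-hydroxyphenyl in place of 3-chlorophenyl. Also open, on these data alone, is how a chain ending in an amine or a carboxylic acid would read at this position.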